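Cytotoxicity series: heptyl and octyl amines on two cores

This account rests on a few compounds, and the source may have more. Where it says the series, first, only, none or still open, it means among the compounds named here.

Compound 1 `CCCCCCCNc1cnc(C(=O)NCc2ccccc2)cn1` and compound 2 `CCCCCCCCNc1cnc(C(=O)NCc2ccccc2)cn1` share one core; compound 3 `CCCCCCCCNc1cncc(C(=O)NCc2ccccc2)n1` carries the octyl chain on the other core, and compound 4 `CCCCCCCNc1cncc(C(=O)NCc2ccccc2)n1` is its heptyl counterpart, not yet measured. In an ADME assay on HeLa cells (Homo sapiens) for cytotoxicity, read by microscopy, with a stated time of 6 days (a lower number here means that less compound is tolerated, a higher number that more compound is tolerated), compound 1 gives only a limit, > 100000 nM. In this assay compound 2 gives 100000 nM. In this assay compound 3 likewise gives only a limit, > 100000 nM. Compound 3 thus sits at the limit of > 100000 nM in this assay, at which 2 of the 3 values shown sit, together with compound 1, and no number separates it from compound 2. The step from compound 3 to compound 4 is hydrogen in place of methyl on a saturated chain carbon, seven bonds along the chain from a nitrogen on an aromatic ring. For the measured compounds named here, the only measured step that bears on it is the reverse change, a number no higher from compound 1 to compound 2 (the limit leaves the size open), which runs from a limit to a number and gives no readable size. Going by the values given here, nothing among the measured pairs points to a move beyond the scatter. Compound 4 is expected to stay at the limit as well, with an estimated step of a number no higher from compound 3 to compound 4 (the limit leaves the size open). The estimate for compound 4 in this assay is 100000 nM, between 50000 nM and 200000 nM, most likely reported again only as a limit.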

Compound 4, minimum cytotoxic concentration: > 100000 nM
Compound 4: a limit, no number; the forecaster's own chance of this, stated with the estimate: 70%; the middle value sits exactly at the limit.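

Compound 3 and compound 4 both stand only as limits in this assay, so no step can be read between them. The compounds shown leave open what number compound 1, compound 3 and compound 4 would reach, and whether heptyl against octyl, or the core, changes it.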